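Isopropyl to 2-(methylsulfanyl)ethyl on the decanoyl amide series

The source may report more compounds than this note shows. Statements on the series, on what has been measured and on what is new or still open speak of the compounds shown alone.

In a functional assay on HeLa cells (Homo sapiens) for cytotoxicity, read by MTT assay, with a stated time of 48 h (a lower number here means a stronger inhibitor, a higher number a weaker inhibitor), compound 1 `CCCCCCCCCC(=O)N[C@H](C(=O)Nc1ccn([C@H]2O[C@@H](CO)[C@H](O)[C@H]2O)c(=O)n1)C(C)C` gives 4990 nM and compound 2 `CCCCCCCCCCCCCCCCCC(=O)N[C@@H](CCSC)C(=O)Nc1ccn([C@H]2O[C@@H](CO)[C@H](O)[C@H]2O)c(=O)n1` gives 9000 nM. Within the data shown here, these two values lie within the scatter of each other, so compound 1 cannot be separated from the only other measured compound.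

Compound 3 `CCCCCCCCCC(=O)N[C@@H](CCSC)C(=O)Nc1ccn([C@H]2O[C@@H](CO)[C@H](O)[C@H]2O)c(=O)n1` carries 2-(methylsulfanyl)ethyl in place of isopropyl on a saturated chain carbon bound to an amide-type nitrogen and a carbonyl carbon. Among the measured compounds shown here, no measured pair isolates this change. Compound 2 also carries 2-(methylsulfanyl)ethyl and gives 9000 nM, so no step beyond the scatter is expected in this assay, in either direction.

The expected change is a 1.2-fold higher number from compound 1 to compound 3 (0.08 log units; within the scatter).

For compound 3 the estimated value is 6000 nM, with an expected range of 2500 nM to 14000 nM.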

Compound 3, half-maximal inhibitory concentration: 3000 nM
Beside the measured number, compound 3's estimate is 2.0-fold (0.30 log units) above it, and the stated range covers the measured number.
By their numbers in this assay, from the lowest: compounds 3, 1 and 2 (each within the scatter of the next, the first and the last beyond it).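

In this assay, 2-(methylsulfanyl)ethyl in place of isopropyl on this saturated chain carbon gives a 1.7-fold lower number from compound 1 to compound 3 (0.22 log units; within the scatter), so the two groups cannot be separated here. With 2-(methylsulfanyl)ethyl held constant, hydrogen in place of octyl gives a 3.0-fold lower number from compound 2 to compound 3 (0.48 log units; beyond the scatter), a modest step and the only one beyond the scatter, which places the first readable difference in the acyl chain and not at this position. No supporting data bear on either step.

Still open, on these data alone, is whether an amine or a carboxylic acid on this saturated chain carbon would keep the number in this range.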